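The source may report more compounds than this note shows. Statements on the series, on what has been measured and on what is new or still open speak of the compounds shown alone.

Measured so far:
compound 1, `Cc1ccccc1-c1nnc(NNC(C)C)s1`, in a functional assay on the whole organism with Mus musculus as the target, in the maximal electroshock model, with a stated time of 1 h (a lower number here means that less compound is needed, a higher number that more compound is needed for the effect), gives 83 mg/kg;
compound 2, `CNN(C)c1nnc(-c2ccccc2C)s1`, in this assay gives 10 mg/kg;
compound 3, `Cc1ccccc1-c1nnc(N(C)NC2CCCC2)s1`, in this assay gives 110 mg/kg.

Compound 3 has the highest number of the three, though its gap to compound 1 lies within the scatter; only compound 2 stands clearly apart from it, by an 11-fold higher number from compound 2 to compound 3 (1.04 log units; beyond the scatter). Compound 4, `Cc1ccccc1-c1nnc(N(C)N(C)C)s1`, is not yet measured. It differs from compound 3 in one place: dimethylamino in place of cyclopentylamino on a nitrogen on an aromatic ring. Going by the values given here, two measured steps bear on this change. The step of an 11-fold higher number from compound 2 to compound 3 (1.04 log units; beyond the scatter) is in effect the reverse of the change in hand, since the cyclopentyl group on the amine nitrogen is removed again, and the step of an 8.3-fold lower number from compound 1 to compound 2 (0.92 log units; beyond the scatter) shows that exchanging (isopropylamino)amino for methyl(methylamino)amino also moved the number down. Among the compounds with values here, compound 4 carries one more methyl group than compound 2, a change with no measured precedent here, so the expectation is set near compound 2 with a wide range. Compound 4 is therefore expected to give 15 mg/kg, between 5 mg/kg and 45 mg/kg, which would mean an expected step of a 7.3-fold lower number from compound 3 to compound 4 (0.87 log units; beyond the scatter).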

Compound 4, dose for half-maximal effect: 25 mg/kg
For compound 4 the middle estimate is 1.7-fold (0.22 log units) below the measured one, within the range that was stated.
By their numbers in this assay, from the lowest: compound 2; then compound 4; then compounds 1 and 3 (each within the scatter of the next).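

In this assay, the step of a 4.4-fold lower number from compound 3 to compound 4 (0.64 log units; beyond the scatter) shows that dimethylamino in place of cyclopentylamino on a nitrogen on an aromatic ring lowers the number, while a 2.5-fold higher number from compound 2 to compound 4 (0.40 log units; beyond the scatter) shows that even methyl in place of hydrogen on an amine nitrogen raises it beyond the scatter. This position therefore responds to a single added methyl, and compound 2, with its remaining hydrogen, keeps the lowest number of the four. The step of a 3.3-fold lower number from compound 1 to compound 4 (0.52 log units; beyond the scatter) adds that (dimethylamino)(methyl)amino also gives a lower number than (isopropylamino)amino on an aromatic carbon, but no measurement offered here explains any of these shifts.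

The compounds shown leave open how an ethyl or a cyclopropyl group on the amine nitrogen would compare with methyl and cyclopentyl. They also leave open whether a hydroxyethyl chain at that nitrogen would follow the same trend.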